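The source may hold more compounds than are shown below. What is called first, only, known or untested is meant among the compounds shown, and "the series" means these compounds.

Measured so far:
- Compound 1, `CCn1c(-c2cnc(C)nc2)nc2c(O[C@H]3CCN(C(=O)C4CC4)C3)ncnc21`, in an ADME assay on the whole organism (Rattus norvegicus, strain Wistar Han) for pharmacokinetics (on this read-out higher numbers stand for higher oral bioavailability and lower numbers for lower oral bioavailability), gives 64%.
- Compound 2, `CCn1c(-c2ccc(C(F)(F)F)nc2)nc2c(O[C@H]3CCN(C(=O)[C@H]4C[C@@H](OC)C4)C3)ncnc21`, in this assay gives 39%.
- Compound 3, `CCn1c(-c2cnc(C)nc2)nc2c(N[C@H]3CCN(C(=O)[C@H]4C[C@@H](OC)C4)C3)ncnc21`, in this assay gives 52%.

Among these three numbers compound 3 stands second highest. Its nearest neighbour is compound 1, whose number lies higher by a margin beyond the scatter; the furthest is compound 2, whose number lies lower, again beyond the scatter. For the measured compounds named here, no pair among the measured compounds differs in only one place, so no single step between them can be read off directly.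

Compound 4, `CCn1c(-c2cnc(C)nc2)nc2c(N[C@H]3CCN(C(=O)C4CC4)C3)ncnc21`, is the next compound and has not yet been measured in this assay. It differs from compound 3 in one place: cyclopropyl in place of 3-methoxycyclobutyl on a carbonyl carbon. The change sits on a carbonyl carbon whose other neighbour is an amide-type nitrogen in a ring, and cut one bond further out it reads (3-methoxycyclobutyl)carbonyl to cyclopropylcarbonyl.

Going by the values given here, no measured pair shows this change on its own. Compound 1, which carries the cyclopropyl, gives 64%, the highest number of the three, which gives some ground for expecting a modest upward step from compound 3 to compound 4, a number 6 percentage points higher from compound 3 to compound 4 (within the scatter), though one that may well stay within the scatter. For compound 4 the estimated result in this assay is 58%, within a range of 40% to 76%.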

Compound 4, oral bioavailability: 55%
Compound 4: middle estimate off by 3 percentage points, on the high side; low and high end bracket the measured number.
By their numbers in this assay, from the lowest: compound 2; then compounds 3, 4 and 1 (each within the scatter of the next, the first and the last beyond it).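

At this position, on a carbonyl carbon whose other neighbour is an amide-type nitrogen in a ring, this assay now gives a direct reading of a single change: cyclopropyl in place of 3-methoxycyclobutyl amounts to a number 3 percentage points higher from compound 3 to compound 4 (within the scatter) and nothing more. Removing the larger group, with its hydrogen-bond acceptor and two defined stereocentres, therefore leaves oral bioavailability within the usual scatter in this pair, and neither group can be ranked over the other on this read-out. Nothing available bears on the reason for this result. The compounds shown leave open whether the same change would read alike in a compound carrying the trifluoromethyl group of compound 2. In this assay, from the compounds shown here alone, it also remains open how a longer chain such as n-butyl, or an amine such as dimethylaminomethyl, would read on the same carbonyl carbon.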